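The source may hold more compounds than are shown below. What is called first, only, known or untested is meant among the compounds shown, and "the series" means these compounds.

Measured compounds:
compound 1, `CCCC[C@H](NC(=O)[C@@H](NC(=O)c1cccc(C(N)=O)c1)C(C)CC)C(=O)CO`, 110 nM
compound 2, `CCC(C)[C@H](NC(=O)c1cccc(C(N)=O)c1)C(=O)N[C@@H](CCc1ccccc1)C(=O)CO`, 88 nM
compound 3, `CCCC[C@H](NC(=O)[C@@H](NC(=O)c1ccc(CN)cc1)C(C)CC)C(=O)CO`, 460 nM

In an assay on isolated protein for binding affinity to cathepsin S (Homo sapiens) (a lower number here means a stronger inhibitor, a higher number a weaker inhibitor), compound 2 has the lowest of the three numbers; compound 1 sits nearest, within the scatter, while compound 3 lies furthest, beyond it. Compound 4, `CCC(C)[C@H](NC(=O)OCc1ccccc1)C(=O)N[C@@H](CCc1ccccc1)C(=O)CO`, differs from compound 2 by benzyloxy in place of 3-carbamoylphenyl on a carbonyl carbon. For the measured compounds named here, only one measured step touches this position: a 4.2-fold higher number from compound 1 to compound 3 (0.62 log units; beyond the scatter), where the 3-carbamoylphenyl group was exchanged for another aryl group. The step of a 1.3-fold lower number from compound 1 to compound 2 (0.10 log units; within the scatter) concerns a different part of the molecule and says little here. Since the group that leaves carries the one hydrogen-bond donor and the group that enters carries none, a modest weakening beyond the scatter is expected, about a 4.0-fold higher number from compound 2 to compound 4 (0.60 log units; beyond the scatter). Compound 4 is therefore estimated at 350 nM, in the range 120 nM to 1000 nM.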

Compound 4, inhibition constant: 811 nM
Compound 4: the middle estimate sits 2.3-fold (0.36 log units) below what was measured, within the range that was stated.
By their numbers in this assay, from the lowest: compounds 2 and 1 (each within the scatter of the next); then compounds 3 and 4 (each within the scatter of the next).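

With benzyloxy in place of 3-carbamoylphenyl on this carbonyl carbon, this assay shows a 9.2-fold higher number from compound 2 to compound 4 (0.96 log units; beyond the scatter), so a second, different replacement of 3-carbamoylphenyl also gives a higher number, beyond the scatter. The earlier compounds shown here showed this only once, with 4-(aminomethyl)phenyl on the core of compound 1; it now also appears on the core of compound 2. No available evidence bears on this result. Open, on these data alone, is how plain phenyl, 3-carboxyphenyl or 4-carbamoylphenyl would read at this carbonyl carbon, and so whether the carbamoyl group itself matters.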